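A Trifluoromethyl for Chloro Swap on an Acylurea

A few compounds are considered here, and "the series" means these few. Any claim that something is new, unique, unknown or untested is made for them only; others in the source may bear on it.

Compound 1 `COc1ccccc1C(=O)NC(=O)Nc1ccc(N2CCCCC2)c(Cl)c1` has been measured in a physicochemical assay for solubility (on this read-out higher numbers stand for higher solubility and lower numbers for lower solubility), where compound 1 gives 3.6 ug/mL. Among the compounds with values here, this is the only plain number among the two values shown. Compound 2 `COc1ccccc1C(=O)NC(=O)Nc1ccc(-c2ccccc2)c(C(C)C)c1` sits at a limit in this assay: compound 2 gives < 1 ug/mL, which is a limit rather than a number, in line with the limit of < 1 ug/mL in this assay, at which 1 of the 2 values shown sits. Within the data shown here, no two measured compounds differ in a single place, so no measured step is available to weigh.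

Compound 3 `COc1ccccc1C(=O)NC(=O)Nc1ccc(N2CCCCC2)c(C(F)(F)F)c1` has not yet been measured in this assay. It differs from compound 1 by trifluoromethyl in place of chloro on an aromatic carbon. Among the measured compounds shown here, with no measured step to rest on, the change is expected to move solubility only modestly, toward the lower side, and a 1.8-fold lower number from compound 1 to compound 3 (0.26 log units; within the scatter) is the estimated step. Compound 3 is expected to come in at 2 ug/mL, within a range of 0.7 ug/mL to 6 ug/mL.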

Compound 3, solubility: 3 ug/mL
Beside the measured number, compound 3's estimate is 1.5-fold (0.18 log units) below it; measured number inside the range.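

In this assay, trifluoromethyl in place of chloro on an aromatic carbon, ortho to a piperidin-1-yl group, gives a 1.2-fold lower number from compound 1 to compound 3 (0.08 log units; within the scatter). Within the data shown here, this is the first single-place step available, and it shows that, with this piperidin-1-yl group in place, the two groups cannot be told apart on this read-out, although the step rests on one pair alone. Nothing shown here bears on why the step is this size.

From the compounds shown here alone, it remains open whether a nitrile or a methoxy group at this same position would give a step beyond the scatter. Also open, going by these compounds, is whether the same swap would read the same way if a carboxylic acid or a primary amine replaced the piperidin-1-yl group.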